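Chloro in Place of Fluoro on Compound 1

The source may report more compounds than this note shows. Statements on the series, on what has been measured and on what is new or still open speak of the compounds shown alone.

Within the data shown here, in a functional assay on SiHa cells (Homo sapiens) for inhibition, read by CCK-8 assay, with a stated time of 72 h, tested at 1 uM (a lower number here means less inhibition of growth, a higher number more inhibition of growth at the concentration tested), compound 1 `CN(C)C(=O)c1cc2cnc(Nc3ccc(NC(=O)C4(C(=O)Nc5ccc(F)cc5)CC4)cc3)nc2n1C1CCCC1` gives 36.5%, the higher of the two numbers measured so far. Compound 2 `CN(C)C(=O)c1cc2cnc(Nc3ccc(N)cn3)nc2n1C1CCCC1` gives -21.2% in this assay, a negative number and a gap to compound 1 that lies beyond the scatter. The next molecule, compound 3 `CN(C)C(=O)c1cc2cnc(Nc3ccc(NC(=O)C4(C(=O)Nc5ccc(Cl)cc5)CC4)cc3)nc2n1C1CCCC1`, keeps all of compound 1 except one substituent: chloro in place of fluoro on an aromatic carbon. This is chloro in place of fluoro on an aromatic carbon, para to a large group, so a 4-fluorophenyl becomes a 4-chlorophenyl. Among the measured compounds shown here, no measured pair of compounds shows this change, so the data offer no direct guide to its size. The expectation therefore starts from compound 1 at 36.5% and assumes that a swap of one heavy atom for another, with no ring, donor or acceptor gained or lost, moves this assay by no step beyond the scatter, in neither direction. The expected change is a number 1.5 percentage points higher from compound 1 to compound 3 (within the scatter). For compound 3 the estimated value is 38%, with an expected range of 20% to 56%.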

Compound 3, percent growth inhibition at one concentration: -0.8%
Compound 3: the middle estimate sits 38.8 percentage points above what was measured, and the stated range ends above it.
By their numbers in this assay, from the lowest: compound 2; then compound 3; then compound 1.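

In this assay, chloro in place of fluoro on the aromatic carbon gives a number 37.3 percentage points lower from compound 1 to compound 3 (beyond the scatter), which shows that this position is sensitive to the identity of a single halogen atom. The earlier compounds shown here could not show this, since compound 1 and compound 2 differ in more than one place, whereas here one heavy atom is exchanged, with no ring, hydrogen-bond donor or hydrogen-bond acceptor gained or lost, and compound 3 reads -0.8% instead of keeping the growth inhibition of compound 1. Nothing available on these compounds accounts for the size of this step, so it stands as an observation without an explanation.

The compounds shown carry only fluoro and chloro at this carbon, so it remains open how plain hydrogen, bromo, methyl, methoxy or trifluoromethyl there would read, and whether fluoro is singular or chloro alone is poorly suited. From the compounds shown here alone, it also remains open whether the same exchange would give a step of similar size on a different core, or whether the gap between the 4-fluorophenyl and the 4-chlorophenyl would persist at other concentrations in this cell line.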